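The compounds below may be only part of what the source reports. "The series", "measured", "known", "first", "only" and "open" are said of these compounds alone.

For the measured compounds named here, in a functional assay on HOP-62 cells (Homo sapiens) for inhibition, read by sulforhodamine B assay, with a stated time of 48 h (a lower number here means a stronger inhibitor of growth, a higher number a weaker inhibitor of growth), compound 1 `O=C(Cc1csc2nc(-c3ccc(Br)cc3)cn12)N/N=C/c1ccccc1` gives 15100 nM and compound 2 `O=C(Cc1csc2nc(-c3ccc(Br)cc3)cn12)N/N=C/c1ccccc1O` gives 3890 nM, the lower of the two numbers so far. Compound 3 `O=C(Cc1csc2nc(-c3ccc(Br)cc3)cn12)N/N=C/c1ccc(O)cc1` differs from compound 2 by 4-hydroxyphenyl in place of 2-hydroxyphenyl on a carbon with a double bond to nitrogen, with 4-hydroxyphenyl in place of 2-hydroxyphenyl on a carbon with a double bond to nitrogen. Going by the values given here, the one measured step that bears on this is a 3.9-fold lower number from compound 1 to compound 2 (0.59 log units; beyond the scatter), where hydroxy takes the place of hydrogen on an aromatic carbon. Among the compounds with values here, no measured compound carries 4-hydroxyphenyl, so only part of that modest step is expected to survive, and the number is expected to rise by an estimated 1.7-fold higher number from compound 2 to compound 3 (0.22 log units; within the scatter). For compound 3 the estimated value is 6500 nM, with a range of 2500 nM to 16000 nM.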

Compound 3, concentration for 50% growth inhibition: 18200 nM
Compound 3: the middle estimate sits 2.8-fold (0.45 log units) below what was measured; the whole stated range lies below it.
By their numbers in this assay, from the lowest: compound 2; then compounds 1 and 3 (each within the scatter of the next).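

Among these compounds, the effect of the hydroxy group depends on where it sits on the ring: 4-hydroxyphenyl in place of 2-hydroxyphenyl gives (a 4.7-fold higher number from compound 2 to compound 3 (0.67 log units; beyond the scatter)). Hydroxy in place of hydrogen to give 4-hydroxyphenyl yields only (a 1.2-fold higher number from compound 1 to compound 3 (0.08 log units; within the scatter)), so the earlier gain is seen with 2-hydroxyphenyl alone. Nothing available explains this difference.

Going by these compounds, it remains open whether a methoxy group or an amine in place of the hydroxy of 2-hydroxyphenyl would keep the lower number of compound 2.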